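The compounds below may be only part of what the source reports. "The series", "measured", "known", "first", "only" and "open" are said of these compounds alone.

Measured in a functional assay on the whole organism (Tail, strain ICR) with Mus musculus as the target, in the tail flick test, with a stated time of 60 min, at a dose of 25 umol/kg by the oral route; on this read-out lower numbers stand for a weaker effect and higher numbers for a stronger effect at the one dose given:

compound 1 `O=C(O)[C@@H]1CCCN1C(=O)CN(c1nc(Cl)nc2[nH]cnc12)C1CC1`: 34.9%
compound 2 `C[C@H](NC(=O)CN(c1nc(Cl)nc2[nH]cnc12)C1CC1)C(=O)O`: 44.6%
compound 3 `C[C@H](NC(=O)CN(c1nc(Cl)nc2[nH]cnc12)C1CC1)C(=O)OCc1ccccc1`: 64.3%

Compound 2 stands second highest of the three numbers in this assay. Its nearest neighbour is compound 1, with a number 9.7 percentage points higher from compound 1 to compound 2 (within the scatter), a step within the scatter, so the two cannot be ranked. The furthest is compound 3, with a number 19.7 percentage points higher from compound 2 to compound 3 (beyond the scatter), a modest step beyond the scatter.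

The next compound, compound 4 `CC(C)C[C@H](NC(=O)CN(c1nc(Cl)nc2[nH]cnc12)C1CC1)C(=O)O`, differs from compound 2 by isopropyl in place of hydrogen on a saturated chain carbon, two bonds along the chain from an amide-type nitrogen and a carbonyl carbon.

Neither measured step bears directly on this change. The step from compound 1 to compound 2 alters the amino-acid part but replaces a ring for an open chain, and it stayed within the scatter. The step from compound 2 to compound 3 sits on the oxygen of the carbonyl, not on the chain carbon, and it went up modestly. Compound 4 keeps the free acid of compound 2 and only enlarges the chain substituent. On this evidence no step beyond the scatter is expected in this assay; the estimated step is a number 3.4 percentage points higher from compound 2 to compound 4 (within the scatter). Compound 4 is therefore expected to give about 48%, with a range from 30% to 66%.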

Compound 4, a percentage reported as activity, at one dose (the size of the read-out at that dose, not a potency): 36.4%
Compound 4: middle estimate off by 11.6 percentage points, on the high side, within the range that was stated.
By their numbers in this assay, from the lowest: compounds 1, 4 and 2 (each within the scatter of the next); then compound 3.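

In this assay, the chain carbon of the free-acid series now has a direct reading: isopropyl in place of hydrogen there, which turns methyl into isobutyl with the carboxylic acid kept, gives a number 8.2 percentage points lower from compound 2 to compound 4 (within the scatter), so the two cannot be ranked. The earlier steps shown here covered only the exchange of a ring for an open chain and the substitution on the oxygen next to the carbonyl, whereas this step shows that isobutyl at this chain carbon produces no change beyond the scatter at the one dose and time tested. No measurement given here offers a reason for this result.

From the compounds shown here alone, whether an amine, a hydroxyl or a longer chain at this same chain carbon would give a step beyond the scatter stays open, and so does the outcome with a phenyl group there. Among these compounds, also open is whether benzyl on the oxygen of the carboxylic acid of compound 4 would repeat the change seen in a number 19.7 percentage points higher from compound 2 to compound 3 (beyond the scatter), which is so far the only step beyond the scatter.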